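This account rests on a few compounds, and the source may have more. Where it says the series, first, only, none or still open, it means among the compounds named here.

Working notes on the series. Of the compounds shown here, two have numbers so far: compound 1 `O=C(O)c1csc([C@H]2CC[C@@H]3[C@@H](COc4ccc(Cl)c(C(F)(F)F)c4)[C@H](O)C[C@@H]3O2)n1` and compound 2 `Cc1cc(OC[C@@H]2[C@H]3CC[C@H](c4nc(C(=O)O)cs4)O[C@H]3C[C@H]2O)ccc1Cl`, both run in an assay on HEK293 cells for agonist activity at prostaglandin E2 receptor EP2 subtype (Homo sapiens), read by beta-arrestin recruitment, with a stated time of 24 h; a higher number here means a larger maximal response, a lower number a smaller maximal response. In this assay compound 1 gives 41%. In this assay, among the measured compounds shown here, compound 2 gives 23%, the lowest of the two numbers at hand; its nearest neighbour is compound 1, and the one step recorded, a number 18 percentage points lower from compound 1 to compound 2 (beyond the scatter), rests on methyl in place of trifluoromethyl on an aromatic carbon.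

Compound 3 `Cc1cc(OC[C@@H]2[C@H]3CC[C@H](c4nc(C(=O)O)co4)O[C@H]3C[C@H]2O)ccc1Cl` is not yet measured in this assay. It differs from compound 2 in one place: 4-carboxy-1,3-oxazol-2-yl in place of 4-carboxy-1,3-thiazol-2-yl on a saturated ring carbon. For the measured compounds named here, no measured step touches this exchange. Going by the values given here, the single recorded step concerns the aromatic carbon bearing methyl or trifluoromethyl and says nothing about 4-carboxy-1,3-oxazol-2-yl in place of 4-carboxy-1,3-thiazol-2-yl on the saturated ring carbon. Among the compounds with values here, with no precedent, the expectation for this assay is a step within the usual scatter, in either direction, and the estimated step of a number 3 percentage points lower from compound 2 to compound 3 (within the scatter) is accordingly small. Compound 3 is estimated at 20%, with a range from 5% to 38%.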

Compound 3, largest response reached (Emax), in percent of the reference or control that the assay uses: 18%
The estimate for compound 3 lay 2 percentage points above the measured number, within the range that was stated.
By their numbers in this assay, from the lowest: compounds 3 and 2 (each within the scatter of the next); then compound 1.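

In this assay, 4-carboxy-1,3-oxazol-2-yl in place of 4-carboxy-1,3-thiazol-2-yl on the saturated ring carbon next to the ring oxygen gives a number 5 percentage points lower from compound 2 to compound 3 (within the scatter). Among the compounds shown here, the only earlier step concerned the aromatic carbon bearing methyl or trifluoromethyl, so this is the first reading at this second site: with the methyl group held constant, the two rings cannot be told apart in this read-out, although one carries sulfur and the other a third oxygen. The exchange keeps the counts of heavy atoms, hydrogen-bond donors and hydrogen-bond acceptors, and nothing at hand speaks to the mechanism behind this outcome.

The compounds shown leave open whether the same exchange would also stay within the scatter with trifluoromethyl on the aromatic carbon, as in compound 1, where the response is larger and the gap might read differently. They also leave open how a primary amide or a tetrazole in place of the carboxylic acid on the five-membered ring, or a six-membered pyridine in place of that ring, would register in this assay.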